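This account rests on a few compounds, and the source may have more. Where it says the series, first, only, none or still open, it means among the compounds named here.

Measured in a functional assay on Gurav cells (Homo sapiens) for inhibition, read by sulforhodamine B assay; a lower number here means a stronger inhibitor of growth, a higher number a weaker inhibitor of growth:

Compound 1 `COc1ccc(-c2ccc(-c3ccc(-c4nc5ccccc5[nH]4)cc3)cc2)cc1`: 38100 nM
Compound 2 `Clc1cccc(-c2ccc(-c3ccc(-c4nc5ccccc5[nH]4)cc3)cc2)c1`: 2190 nM
Compound 3 `COc1ccc(-c2ccc(-c3ccc(-c4nc5ccccc5[nH]4)cc3)cc2)cc1OC`: 9230 nM

Compound 3 stands second highest of these three numbers. Its nearest neighbour is reached by a 4.1-fold lower number from compound 1 to compound 3 (0.62 log units; beyond the scatter), its furthest by a 4.2-fold higher number from compound 2 to compound 3 (0.62 log units; beyond the scatter); both steps lie beyond the scatter. The largest step among the measured compounds is a 17-fold lower number from compound 1 to compound 2 (1.24 log units; beyond the scatter).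

Compound 4 `COc1ccc(-c2ccc(-c3ccc(-c4nc5c(O)cccc5[nH]4)cc3)cc2)cc1OC` differs from compound 3 by a single change: hydroxy in place of hydrogen on an aromatic carbon. None of the three measured steps bears on this change. Each of them alters the outermost aryl group of the shared core, whereas the hydroxy of compound 4 enters on the fused ring system at the other end, which is the same in compound 1, compound 2 and compound 3. Among the measured compounds shown here, with no step touching that part of the molecule, the expectation for compound 4 rests on compound 3 alone, and the step of a 1.0-fold lower number from compound 3 to compound 4 (0.01 log units; within the scatter) is expected to stay within the scatter. Compound 4 is therefore estimated at 9000 nM in this assay, with a range from 2500 nM to 32000 nM.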

Compound 4, concentration for 50% growth inhibition: 1110 nM
Beside the measured number, compound 4's estimate is 8.1-fold (0.91 log units) above it, and the stated range ends above it.
By their numbers in this assay, from the lowest: compounds 4 and 2 (each within the scatter of the next); then compound 3; then compound 1.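

In this assay, the 1H-benzimidazol-2-yl end of the shared core proves responsive: changing it to 4-hydroxy-1H-benzimidazol-2-yl gives an 8.3-fold lower number from compound 3 to compound 4 (0.92 log units; beyond the scatter), a stronger inhibitor of growth. Among the compounds shown here, the earlier steps all altered the outermost aryl group, so this is the first sign that a single change at the other end of the molecule can also move the number beyond the scatter. Nothing available explains why this hydroxy has this effect.

The compounds shown leave open whether an amine, a methoxy or a carboxylic acid at this same place would give a comparable step. They also leave open whether hydroxy in place of hydrogen would act in the same way with 3-chlorophenyl or 4-methoxyphenyl as the outer group, since it is shown only with 3,4-dimethoxyphenyl.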